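Ring ether in place of the prenyl chain

A few compounds are considered here, and "the series" means these few. Any claim that something is new, unique, unknown or untested is made for them only; others in the source may bear on it.

Compound 1 `COCC(C)Oc1cccc2ccc(N)nc12`: 606 nM
Compound 2 `CC(C)Oc1cccc2ccc(N)nc12`: 437 nM
Compound 3 `CC(C)=CCOc1cccc2ccc(N)nc12`: > 2000 nM

In an assay on cells with melanin-concentrating hormone receptor 1 (Homo sapiens) as the target, read by radioligand binding (a higher number here means a weaker inhibitor, a lower number a stronger inhibitor), compound 1 gives 606 nM and compound 2 gives 437 nM, a difference a 1.4-fold lower number from compound 1 to compound 2 (0.14 log units; within the scatter). For compound 3 this assay reports only a limit, > 2000 nM. This limit of > 2000 nM in this assay, at which 1 of the 3 values shown sits, is reached by an at least 3.3-fold higher number from compound 1 to compound 3 (0.51 log units; beyond the scatter) and by an at least 4.5-fold higher number from compound 2 to compound 3 (0.66 log units; beyond the scatter). Compound 4 `Nc1ccc2cccc(OCC3CCOC3)c2n1` carries oxolan-3-yl in place of 2-methylprop-1-en-1-yl on a saturated chain carbon bound to an oxygen on an aromatic ring. Both steps toward compound 3 went upward and beyond the scatter, so the return toward a saturated ether side chain is expected to bring the number back down, though from a limit the true size of the step is uncertain. For compound 4 the estimate is 700 nM, between 300 nM and 2500 nM, a step of an at least 2.8-fold lower number from compound 3 to compound 4 (0.45 log units; beyond the scatter).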

Compound 4, half-maximal inhibitory concentration: 115 nM
The estimate for compound 4 lay 6.1-fold (0.78 log units) above the measured number; the whole stated range lies above it.
By their numbers in this assay, from the lowest: compound 4; then compounds 2 and 1 (each within the scatter of the next). At a limit, above all of these: compound 3.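

In this assay, (oxolan-3-yl)methyl on an oxygen on an aromatic ring improves on both open-chain saturated ethers, with a 3.8-fold lower number from compound 2 to compound 4 (0.58 log units; beyond the scatter) and a 5.3-fold lower number from compound 1 to compound 4 (0.72 log units; beyond the scatter), so a saturated side chain here can do more than merely recover the level of those two ethers. Against the 3-methylbut-2-en-1-yl ether, the change gives an at least 17-fold lower number from compound 3 to compound 4 (1.24 log units; beyond the scatter). Compound 3 stands at a limit, so that step fixes only a minimum size: the limit of > 2000 nM in this assay, at which 1 of the 4 values shown sits.

The compounds shown leave open whether the ring alone or its oxygen matters, which a cyclopentylmethyl group would separate. On these data alone, how an amine on the ring of this side chain would read also remains open.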